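Notes on replacing the amine of compound 3 with piperidine

The source may hold more compounds than are shown below. What is called first, only, known or untested is meant among the compounds shown, and "the series" means these compounds.

Measured so far in a functional assay on PC-3 cells (Homo sapiens) for inhibition, read by MTT assay, with a stated time of 48 h, tested at 10 uM; a lower number here means less inhibition of growth, a higher number more inhibition of growth at the concentration tested
- compound 1 `Cc1cc(=O)c2c(O)c(CN3CCC(N4CCCCC4)CC3)c(O)c([C@H]3CCN(C)C[C@H]3O)c2o1` gives 17%
- compound 2 `CCOC(=O)N1CCN(Cc2c(O)c([C@H]3CCN(C)C[C@H]3O)c3oc(C)cc(=O)c3c2O)CC1` gives 1%
- compound 3 `Cc1cc(=O)c2c(O)c(CN3CC(O)CC3C(=O)O)c(O)c([C@H]3CCN(C)C[C@H]3O)c2o1` gives 0%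

Compound 3 (0%) sits at the low end of the three numbers in this assay together with compound 2, and compound 1 stands beyond the scatter above it.

Compound 4 `Cc1cc(=O)c2c(O)c(CN3CCCCC3)c(O)c([C@H]3CCN(C)C[C@H]3O)c2o1` keeps the shared core and carries piperidin-1-yl in place of 2-carboxy-4-hydroxypyrrolidin-1-yl on a saturated chain carbon bound to an aromatic carbon.

Going by the values given here, only one measured step touches this place: a number 1 percentage points lower from compound 2 to compound 3 (within the scatter) was an exchange of 4-(ethoxycarbonyl)piperazin-1-yl for the group that now leaves. It shows that one such exchange need not move the number, but neither compound in that step carries piperidin-1-yl. The closest guide is compound 1, whose group at this place itself holds piperidin-1-yl and which gives 17% in this assay as the upper reference. Among the compounds with values here, no measured step leads directly to compound 4, so a small rise is expected, with compound 1 as a rough ceiling.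

The estimated step is a number 8 percentage points higher from compound 3 to compound 4 (within the scatter) in an upward direction. For compound 4 the expected value is 8% within an estimated range of 0% to 22% for now.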

Compound 4, percent growth inhibition at one concentration: 14%
The estimate for compound 4 lay 6 percentage points below the measured number; measured number inside the range.
By their numbers in this assay, from the lowest: compounds 3 and 2 (each within the scatter of the next); then compounds 4 and 1 (each within the scatter of the next).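

In this assay the group on a saturated chain carbon bound to an aromatic carbon does matter: piperidin-1-yl in place of 2-carboxy-4-hydroxypyrrolidin-1-yl gives a number 14 percentage points higher from compound 3 to compound 4 (beyond the scatter) and piperidin-1-yl in place of 4-(ethoxycarbonyl)piperazin-1-yl gives a number 13 percentage points higher from compound 2 to compound 4 (beyond the scatter), which the exchange between those two groups alone did not reveal. The piperidin-1-yl carried on the saturated ring of compound 1 adds nothing that can be read, since hydrogen in its place gives a number 3 percentage points lower from compound 1 to compound 4 (within the scatter), so the simple piperidin-1-yl of compound 4 stands level with the larger group within the scatter. Nothing measured on these compounds gives a reason for these steps.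

The compounds shown leave open which part of 2-carboxy-4-hydroxypyrrolidin-1-yl goes with the low number, as a plain pyrrolidin-1-yl or a pyrrolidin-1-yl with only the carboxylic acid or only the hydroxyl would be needed to separate ring size from those two groups. On these data alone, it also stays open whether morpholin-4-yl or an open-chain amine such as diethylamino would hold the number of compound 4 at this place.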